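Furan Replaces Chlorophenyl in a Thiazole Carboxamide Series

This account rests on a few compounds, and the source may have more. Where it says the series, first, only, none or still open, it means among the compounds named here.

Three compounds that share one core and differ only in the group on the carbonyl carbon of the amide have been measured in a functional assay on Raji cells (Homo sapiens) for antiproliferative activity, read by CCK-8 assay, with a stated time of 72 h, tested at 40 uM; on this read-out lower numbers stand for less inhibition and higher numbers for more inhibition at the one concentration tested (going by the name of the read-out). Compound 3 `CN1CCN(c2ccc(Nc3nc(-c4cccc(NC(=O)c5ccc(Cl)cc5)c4)sc3C(N)=O)cc2)CC1` gives 92.6%, the highest of the three numbers. Compound 1 `CN1CCN(c2ccc(Nc3nc(-c4cccc(NC(=O)c5ccc(C(C)(C)C)cc5)c4)sc3C(N)=O)cc2)CC1` gives 12.1%, and compound 2 `CN1CCN(c2ccc(Nc3nc(-c4cccc(NC(=O)c5cccc(F)c5)c4)sc3C(N)=O)cc2)CC1` gives 2.78%; these two lie within the scatter of each other, as a number 9.3 percentage points lower from compound 1 to compound 2 (within the scatter) shows. The steps to compound 3 are large: a number 80.5 percentage points higher from compound 1 to compound 3 (beyond the scatter) and a number 89.8 percentage points higher from compound 2 to compound 3 (beyond the scatter).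

Compound 4 `CN1CCN(c2ccc(Nc3nc(-c4cccc(NC(=O)c5ccco5)c4)sc3C(N)=O)cc2)CC1` has not yet been measured in this assay. It differs from compound 3 in one place: furan-2-yl in place of 4-chlorophenyl on a carbonyl carbon.

For the measured compounds named here, no measured step exchanges an aryl amide for a heteroaryl one, so no step bears directly on this change. What the measured steps do show is that the group on this carbonyl carbon can move the read-out across nearly its whole range, and that only compound 3 reaches a high number. On that basis compound 4 is expected to fall well short of compound 3, with a number 57.6 percentage points lower from compound 3 to compound 4 (beyond the scatter) as the estimated step, though a wide range is needed. The estimate for compound 4 in this assay is 35%, between 3% and 85%.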

Compound 4, a percentage reported as inhibition, at one concentration (the size of the read-out at that concentration, not a potency): 84.3%
Beside the measured number, compound 4's estimate is 49.3 percentage points below it; the measured number falls inside the stated range.
By their numbers in this assay, from the lowest: compounds 2 and 1 (each within the scatter of the next); then compounds 4 and 3 (each within the scatter of the next).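

In this assay, furan-2-yl on this carbonyl carbon gives a high number as 4-chlorophenyl does, with a number 8.3 percentage points lower from compound 3 to compound 4 (within the scatter) as the step, so a high number at this position is no longer confined to compound 3 and needs neither chlorine nor a six-membered aromatic ring of carbon only. The same group stands far from the two low compounds, with a number 81.5 percentage points higher from compound 2 to compound 4 (beyond the scatter) and a number 72.2 percentage points higher from compound 1 to compound 4 (beyond the scatter) as the steps. A six-membered aromatic ring of carbon only now appears at both ends of the range, in compound 3 at the high end and in compounds 1 and 2 at the low end, and the data offer no explanation for how these groups sort.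

On these data alone, whether the oxygen of the furan-2-yl group matters remains open, and a thiophen-2-yl or unsubstituted phenyl group on this carbonyl carbon would bear on that, as a furan-2-yl group carrying an amine or a carboxylic acid would bear on how much that ring can take. As far as these compounds go, compounds 3 and 4 are also read at one concentration only, so how they compare in potency stays open.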